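The source may hold more compounds than are shown below. What is called first, only, known or untested is meant among the compounds shown, and "the series" means these compounds.

Compound 2 `COc1ccc(C2CC(c3cc(Cl)c(C)cc3O)=NN2c2ccc(S(N)(=O)=O)cc2)cc1OC` is one of two analogues measured in a functional assay on SR cells (Homo sapiens) for antiproliferative activity, with a stated time of 48 h; a higher number here means that more compound is tolerated, a lower number that less compound is tolerated; there compound 2 gives > 100000 nM, which is a limit of the assay rather than a number. Compound 1 `Cc1cc(O)c(C2=NN(c3ccc(S(N)(=O)=O)cc3)C(c3ccccc3Cl)C2)cc1Cl` gives > 100000 nM, also a limit. Within the data shown here, the only measured step, a step that the two limits leave unreadable from compound 1 to compound 2, therefore has no readable size. Compound 3 `COc1ccc(C2CC(c3cc(Cl)c(C)cc3O)=NN2c2ccc(S(N)(=O)=O)cc2)c(OC)c1OC` differs from compound 2 by methoxy in place of hydrogen on an aromatic carbon. Because the limit of > 100000 nM in this assay, at which 2 of the 2 values shown sit, places every measured value at the limit, no direction or size of change can be drawn from these data. Compound 3 is expected to sit at that limit as well, estimated at 100000 nM, between 30000 nM and 300000 nM, a step of a number no higher from compound 2 to compound 3 (the limit leaves the size open).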

Compound 3, concentration lethal to 50% of the cells: > 100000 nM
Compound 3 ended at the assay's limit (the forecaster's own chance of this, stated with the estimate: 80%); the middle value sits exactly at the limit.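

No step can be read among compound 1, compound 2 and compound 3, as each result is a limit and not a number: the limit of > 100000 nM in this assay, at which 3 of the 3 values shown sit.

The compounds shown leave open whether 2-chlorophenyl, 3,4-dimethoxyphenyl or 2,3,4-trimethoxyphenyl makes any difference in this assay.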